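A Small Swap on a Sulfonyl Sulfur

A few compounds are considered here, and "the series" means these few. Any claim that something is new, unique, unknown or untested is made for them only; others in the source may bear on it.

Three related compounds have been measured in an ADME assay on a cell-free system (plasma, Homo sapiens); on this read-out lower numbers stand for a smaller free fraction and higher numbers for a larger free fraction: compound 1 `CCCS(=O)(=O)c1cccc(C#Cc2cc(Cl)ccc2OCC(=O)O)c1` gives 0.008, compound 2 `CN(C)S(=O)(=O)c1ccc(F)c(C#Cc2cc(Cl)ccc2OCC(=O)O)c1` gives 0.009, and compound 3 `COCCN(C)S(=O)(=O)c1ccc(C)c(C#Cc2cc(Cl)ccc2OCC(=O)O)c1` gives 0.006. Compound 2 therefore stands level with the other two, as all three values lie within the usual scatter of repeated measurements. Compound 4 `CCCS(=O)(=O)c1ccc(F)c(C#Cc2cc(Cl)ccc2OCC(=O)O)c1` carries propyl in place of dimethylamino on a sulfonyl sulfur. Within the data shown here, no measured pair shows this change alone. Still, compound 1 also has a propylsulfonyl group and gives 0.008, so no step beyond the scatter is expected in this assay. The expected change is small, a 1.3-fold lower number from compound 2 to compound 4 (0.11 log units; within the scatter). Compound 4 is estimated at 0.007, within a range from 0.004 to 0.012.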

Compound 4, unbound fraction: 0.01
Estimate against measurement, compound 4: 1.4-fold (0.15 log units) below; the measured number falls inside the stated range.
By their numbers in this assay, from the lowest: compounds 3, 1, 2 and 4 (each within the scatter of the next).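

Among these compounds, this pair isolates the swap on the sulfonyl sulfur for the first time: in this assay, propyl in place of dimethylamino gives a 1.1-fold higher number from compound 2 to compound 4 (0.05 log units; within the scatter), so the two groups cannot be told apart here. A second single change, fluoro in place of hydrogen on an aromatic carbon, gives a 1.3-fold higher number from compound 1 to compound 4 (0.10 log units; within the scatter), which also cannot be told apart from no difference. No supporting data bear on these results.

As far as these compounds go, whether an amine or a longer chain such as hexyl on the sulfonyl sulfur would give a step beyond the scatter remains open.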